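Moving the Ring Nitrogen: From Compound 2 to Compound 3

The source may hold more compounds than are shown below. What is called first, only, known or untested is meant among the compounds shown, and "the series" means these compounds.

The two measured compounds:
compound 1, `CN(C)CCCN(Cc1ccccc1)c1cccc(C(=O)N2CCc3ccc(OS(N)(=O)=O)cc3C2)c1`, gives 23.8%
compound 2, `CCN(Cc1ccccn1)c1ccc(C(=O)N2CCc3ccc(OS(N)(=O)=O)cc3C2)cc1`, gives 42.5%

Both numbers come from an assay on HEK293 cells for inhibition of Steryl-sulfatase (Homo sapiens), tested at 0.1 uM; a lower number here means a weaker effect, a higher number a stronger effect of the compound at the concentration tested. Of the two, compound 2 stands highest, and its nearest neighbour is compound 1, which sits below it by a gap that is beyond the usual scatter of this measurement. For the measured compounds named here, no pair of these two differs in only one place, so no single structural step between them can be read off.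

Compound 3, `CCN(Cc1ccncc1)c1ccc(C(=O)N2CCc3ccc(OS(N)(=O)=O)cc3C2)cc1`, is not yet measured. It is built from exactly the same atoms as compound 2, joined differently: pyridin-4-yl in place of pyridin-2-yl on a saturated chain carbon bound to a nitrogen on an aromatic ring. Going by the values given here, nothing among the measured compounds shows what this kind of rearrangement does in this assay, so the step from compound 2 to compound 3 cannot be sized from data. The expectation is therefore a step of about a number 2.5 percentage points lower from compound 2 to compound 3 (within the scatter), that is, none beyond the scatter. On that basis compound 3 is estimated at 40%, with a plausible range from 20% to 60%.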

Compound 3, a percentage reported as inhibition, at one concentration (the size of the read-out at that concentration, not a potency): 47%
Compound 3: middle estimate off by 7 percentage points, on the low side; measured number inside the range.
By their numbers in this assay, from the lowest: compound 1; then compounds 2 and 3 (each within the scatter of the next).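

In this assay, pyridin-4-yl in place of pyridin-2-yl on a saturated chain carbon bound to a nitrogen on an aromatic ring gives a step of a number 4.5 percentage points higher from compound 2 to compound 3 (within the scatter). This is the first pair shown that differs in one place, and it shows that, at this single concentration, the two ring attachments cannot be told apart, even though the ring nitrogen sits differently in each. No separate measurement bears on why the two compounds read alike.

As far as these compounds go, whether this tolerance extends to other rings remains open, since nothing shows what a pyrimidine ring or a thiophene ring would do on the same chain carbon, or what isopropyl would do in place of the ethyl on the shared amine nitrogen. Compound 1 differs from compound 2 and compound 3 in more than one place, so the steps that connect it to them cannot be read, and the read-out, taken at one concentration, gives no potency for any of the three.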